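Triazole Diaryl Analogues Tested for Cytotoxicity in PC-12 Cells

The source may report more compounds than this note shows. Statements on the series, on what has been measured and on what is new or still open speak of the compounds shown alone.

Measured compounds:
Compound 1, `CC(C)c1ccc(-n2nc(-c3ccc(C(F)(F)F)cc3O)nc2-c2ccccc2O)cc1`, in a functional assay on PC-12 cells (Rattus norvegicus) for cytotoxicity, read by MTT assay, with stated times of 2 h and 24 h, tested at 10 uM (on this read-out higher numbers stand for a stronger effect at the one concentration tested and lower numbers for a weaker effect), compound 1 gives 108%.
Compound 2, `Oc1cc(C(F)(F)F)ccc1-c1nc(-c2ccccc2O)n(-c2ccc(Cl)cc2)n1`, compound 2 gives 96.1%.
Compound 3, `Oc1cc(C(F)(F)F)ccc1-c1nc(-c2ccccc2O)n(-c2ccc(C(F)(F)F)cc2)n1`, compound 3 gives 102%.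

Compound 3 stands with its number between those of compound 1 and compound 2, and both of its steps to them lie within the scatter: a number 6 percentage points lower from compound 1 to compound 3 (within the scatter) and a number 5.9 percentage points higher from compound 2 to compound 3 (within the scatter). Within the data shown here, the only step beyond the scatter among the three is a number 11.9 percentage points lower from compound 1 to compound 2 (beyond the scatter), which is modest.

Compound 4, `COc1cccc(-n2nc(-c3ccc(C(F)(F)F)cc3O)nc2-c2ccccc2O)c1`, is the unmeasured member. It differs from compound 3 in one place: 3-methoxyphenyl in place of 4-(trifluoromethyl)phenyl on an aromatic nitrogen.

All three measured steps change the group on the aryl ring attached to the aromatic nitrogen of the shared core, and none of them moved the read-out far; even the largest was modest. Among the measured compounds shown here, the change to compound 4 again alters only that aryl ring, so no step beyond the scatter is expected in this assay, in either direction. Compound 4 is therefore expected to give about 100%, with a range from 85% to 115%. The expected step is a number 2 percentage points lower from compound 3 to compound 4 (within the scatter).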

Compound 4, a percentage reported as activity, at one concentration (the size of the read-out at that concentration, not a potency): 106%
Compound 4: middle estimate off by 6 percentage points, on the low side; the measured number falls inside the stated range.
By their numbers in this assay, from the lowest: compounds 2, 3, 4 and 1 (each within the scatter of the next, the first and the last beyond it).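

In this assay, among these compounds, compound 4 brings the first aryl group that is not 4-substituted, and the first whose substituent contains oxygen, yet all three of its steps stay small: a number 4 percentage points higher from compound 3 to compound 4 (within the scatter), a number 9.9 percentage points higher from compound 2 to compound 4 (within the scatter) and a number 2 percentage points lower from compound 1 to compound 4 (within the scatter). Among the compounds shown here, at this aromatic nitrogen, then, exchanging 4-(trifluoromethyl)phenyl, with 0 hydrogen-bond acceptors, for 3-methoxyphenyl, with 1 hydrogen-bond acceptor, produces no step beyond the scatter, so the insensitivity seen among the 4-substituted aryl groups extends to this different kind of aryl group, and compound 4 lies within the scatter of both compound 1 and compound 2, the one pair that lie beyond it from each other. No measurement is available to explain this lack of response to the change.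

Going by these compounds, it remains open whether 4-methoxyphenyl would behave like 3-methoxyphenyl at this nitrogen, and whether an amine, a carboxylic acid or a longer alkyl chain on this aryl ring would produce a step beyond the scatter in this assay. The compounds shown also leave open what replacing either hydroxyl group on the shared core with a methoxy group or an amine would do.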